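Trifluoromethyl for methoxy in the chlorophenyl pair

The source may report more compounds than this note shows. Statements on the series, on what has been measured and on what is new or still open speak of the compounds shown alone.

In a functional assay on MCF7 cells (Homo sapiens) for antiproliferative activity, read by MTT assay, with a stated time of 48 h (on this read-out higher numbers stand for weaker inhibition and lower numbers for stronger inhibition), compound 2 (`COc1ccc2[nH]c(-c3cn(-c4ccccc4)nc3-c3ccc(Cl)cc3)nc2c1`) gives 1760 nM and stands within the scatter of compound 1 (`Fc1ccc(-c2nn(-c3ccccc3)cc2-c2nc3cc(C(F)(F)F)ccc3[nH]2)cc1`) at 2130 nM on the same read-out. Compound 3 (`FC(F)(F)c1ccc2[nH]c(-c3cn(-c4ccccc4)nc3-c3ccc(Cl)cc3)nc2c1`) has not yet been measured. It carries trifluoromethyl in place of methoxy on an aromatic carbon, and this aromatic carbon belongs to the part of the shared core that is a fused system of two rings.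

Among the compounds with values here, no measured step isolates this change, so the series offers no direct calibration. Compound 1 also bears trifluoromethyl, and it differs from compound 2 in more than one place, yet the two numbers remain within the scatter of each other. The expected step of a 1.0-fold higher number from compound 2 to compound 3 (0.01 log units; within the scatter) is therefore none beyond the scatter, with no direction favoured. In this assay compound 3 is estimated at 1800 nM with an expected range from 750 nM to 4300 nM as the likely span.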

Compound 3, half-maximal inhibitory concentration: 4210 nM
Beside the measured number, compound 3's estimate is 2.3-fold (0.37 log units) below it; the measured number falls inside the stated range.
By their numbers in this assay, from the lowest: compounds 2, 1 and 3 (each within the scatter of the next, the first and the last beyond it).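

In this assay, within the data shown here, a 2.4-fold higher number from compound 2 to compound 3 (0.38 log units; beyond the scatter) gives the first reading of trifluoromethyl in place of methoxy on an aromatic carbon of the fused system of two rings, and it shows a modest loss of inhibition that the earlier comparison of compounds differing in more than one place could not isolate. With trifluoromethyl held at this position, chloro in place of fluoro on an aromatic carbon gives a 2.0-fold higher number from compound 1 to compound 3 (0.30 log units; within the scatter), which does not separate the two halogens on this read-out. No measurement bearing on the reason for the methoxy to trifluoromethyl step is available.

Going by these compounds, it remains open whether this step keeps its size with fluoro in place of chloro. On these data alone, how an amine or a carboxylic acid at this aromatic carbon would compare with methoxy and trifluoromethyl also remains open, and a single pair defines no trend for this position.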